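The compounds below may be only part of what the source reports. "The series", "measured", "known", "first", "only" and "open" are said of these compounds alone.

Among the measured compounds shown here, compound 2 `COc1ccc(/C=C2/SC(N3CCC[C@H]3C(=O)Nc3ccc4ncnc(Nc5cccc(Cl)c5)c4c3)=NC2=O)cc1` is one of two compounds measured in a functional assay on HepG2 cells (Homo sapiens) for antiproliferative activity, read by MTT assay (on this read-out higher numbers stand for weaker inhibition and lower numbers for stronger inhibition), and in this assay compound 2 gives 19000 nM, the single plain number reported. Compound 1 `O=C1N=C(N2CCC[C@H]2C(=O)Nc2ccc3ncnc(Nc4cccc(Cl)c4)c3c2)S/C1=C/c1ccc(Br)s1` gives in this assay > 50000 nM, which is a limit of the assay rather than a number. The step of an at least 2.6-fold lower number from compound 1 to compound 2 (0.42 log units; beyond the scatter) is accordingly known only as a lower bound, set by the limit of > 50000 nM in this assay, at which 1 of the 2 values shown sits. Compound 3 `O=C1N=C(N2CCC[C@H]2C(=O)Nc2ccc3ncnc(Nc4cccc(Cl)c4)c3c2)S/C1=C/c1cccc(Cl)c1` has not yet been measured; it differs from compound 2 at one place: 3-chlorophenyl in place of 4-methoxyphenyl on a double-bonded chain carbon bound to a double-bonded ring carbon. For the measured compounds named here, the one measured step sits at this same place and shows that the ring there can shift the read-out at least modestly. Compound 3 is expected to sit weaker than compound 2 because compound 1, which carries a bromine-bearing ring at this place, gives > 50000 nM. Compound 3 is therefore estimated at about 30000 nM, within 12000 nM to 80000 nM, an expected step of a 1.6-fold higher number from compound 2 to compound 3 (0.20 log units; within the scatter).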

Compound 3, half-maximal inhibitory concentration: 27600 nM
Compound 3: the middle estimate sits 1.1-fold (0.04 log units) above what was measured; measured number inside the range.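

In this assay, two differently substituted benzene rings cannot be told apart at this place, even though the change removes the methoxy oxygen, a hydrogen-bond acceptor, and brings in chlorine: a 1.5-fold higher number from compound 2 to compound 3 (0.16 log units; within the scatter). The earlier step therefore does not extend to every replacement of the 5-bromothiophen-2-yl ring, as the new step shows only a floor that does not clear the scatter: an at least 1.8-fold lower number from compound 1 to compound 3 (0.25 log units; that floor lies within the scatter). That step cannot be pinned down further, since one of its ends is a limit and not a number: the limit of > 50000 nM in this assay, at which 1 of the 3 values shown sits.

As far as these compounds go, it remains open whether the bromine or the thiophene ring matters in the 5-bromothiophen-2-yl group, which a plain thiophene ring would help separate. From the compounds shown here alone, it is also open whether a phenyl ring carrying an amine or a carboxylic acid at this place would shift the read-out beyond the scatter.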